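Anilino to 4-nitrophenyl on the carbonyl carbon

The source may report more compounds than this note shows. Statements on the series, on what has been measured and on what is new or still open speak of the compounds shown alone.

Measured in a functional assay on SK-LU-1 cells (Homo sapiens) for antiproliferative activity, read by sulforhodamine B assay, with a stated time of 48 h; a higher number here means a weaker inhibitor, a lower number a stronger inhibitor:
Compound 1 `CC1=CC[C@H](C(C)C)c2cc(C)c(OC(=O)c3ccc(C)cc3)cc21`: 33900 nM
Compound 2 `CC1=CC[C@H](C(C)C)c2cc(C)c(OC(=O)Nc3ccccc3)cc21`: 120 nM

Compound 2 holds the lower of the two numbers, at 120 nM. Going by the values given here, the one measured step, a 280-fold lower number from compound 1 to compound 2 (2.45 log units; beyond the scatter), puts anilino in place of 4-methylphenyl on a carbonyl carbon, and it is large and beyond the scatter. Compound 3 `CC1=CC[C@H](C(C)C)c2cc(C)c(OC(=O)c3ccc([N+](=O)[O-])cc3)cc21` has 4-nitrophenyl in place of anilino on that carbonyl carbon: 4-nitrophenyl in place of anilino on a carbonyl carbon. Compound 3 thus gives up anilino, which compound 1 also lacks at 33900 nM. Among the compounds with values here, that measured step therefore bears on this change, read in reverse, although no measurement yet covers 4-nitrophenyl itself. A large move to a higher number in this assay is expected, and the estimated step is a 100-fold higher number from compound 2 to compound 3 (2.00 log units; beyond the scatter). The estimate for compound 3 is 12000 nM, with an expected range from 2500 nM to 45000 nM.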

Compound 3, half-maximal inhibitory concentration: 42900 nM
For compound 3 the middle estimate is 3.6-fold (0.55 log units) below the measured one; the measured number falls inside the stated range.
By their numbers in this assay, from the lowest: compound 2; then compounds 1 and 3 (each within the scatter of the next).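

In this assay, the result shows that the effect of anilino on this carbonyl carbon does not depend on one particular aryl comparison: 4-nitrophenyl in its place gives a 360-fold higher number from compound 2 to compound 3 (2.55 log units; beyond the scatter). Between the two compounds with a substituted phenyl directly on the carbonyl carbon, nitro in place of methyl on an aromatic carbon gives a 1.3-fold higher number from compound 1 to compound 3 (0.10 log units; within the scatter), so these two compounds stand within the scatter of each other. Among these three compounds, only compound 2 carries anilino, and only compound 2 has a low number in this assay. From the compounds shown here alone, it remains open whether that low number would persist with benzylamino, cyclohexylamino or 4-nitroanilino on the same carbonyl carbon. No evidence is available to explain these differences.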